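The compounds below may be only part of what the source reports. "The series", "measured", "known", "first", "only" and "open" are said of these compounds alone.

Measured compounds:
Compound 1, `CC#CCn1c(N2CCC[C@@H](N)C2)cc(=O)n(Cc2ccc(Cl)c(C(=O)O)c2)c1=O` – > 100 nM
Compound 2, `CC#CCn1c(N2CCC[C@@H](N)C2)cc(=O)n(Cc2cccc(C(=O)O)c2F)c1=O` – "not determined" (no result reported)
Compound 3, `CC#CCn1c(N2CCC[C@@H](N)C2)cc(=O)n(Cc2ccc(F)c(C(=O)OC)c2)c1=O` – > 100 nM

The three compounds share one core and were run in an assay on isolated protein for inhibition of Dipeptidyl peptidase 9 (Homo sapiens), read by fluorescence, with stated times of 15 min and 20 min; a lower number here means a stronger inhibitor, a higher number a weaker inhibitor. For compound 3 the result is a limit, > 100 nM, not a number. Compound 1 also sits at a limit, > 100 nM. Compound 2 carries no single number in this assay. Compound 3 therefore stands where most of the shown values stand, at the limit of > 100 nM in this assay, at which 2 of the 3 values shown sit; no pair of measured compounds differs in one place only, so no measured step is available.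

Compound 4, `CC#CCn1c(N2CCC[C@@H](N)C2)cc(=O)n(Cc2ccc(F)c(C(=O)O)c2)c1=O`, differs from compound 3 by hydrogen in place of methyl on an oxygen next to a carbonyl group. With compound 1 and compound 3 both at the limit, no step beyond the scatter is expected in this assay, in either direction. The step from compound 3 to compound 4 is estimated as a step that the limit leaves unreadable from compound 3 to compound 4. Compound 4 is expected to give about 400 nM, with a range from 100 nM to 5000 nM, most likely reported again as a limit.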

Compound 4, half-maximal inhibitory concentration: > 100 nM
Compound 4: only a limit was reported (the forecaster's own chance of this, stated with the estimate: 85%); the middle value is on the limit's open side.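

In this assay, among the compounds shown here, compound 4 gives only a limit, > 100 nM, so no step from compound 3 or compound 1 to compound 4 can be read: the limit of > 100 nM in this assay, at which 3 of the 4 values shown sit. The compounds shown leave open whether methoxycarbonyl and carboxy, or fluoro and chloro, differ at all in this assay.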